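A few compounds are considered here, and "the series" means these few. Any claim that something is new, unique, unknown or untested is made for them only; others in the source may bear on it.

Measured so far in an assay on isolated protein for inhibition of Trypsin (Homo sapiens); a lower number here means a stronger inhibitor, a higher number a weaker inhibitor:
- compound 1 `CCOc1cc([C@@H](Nc2ccc3cnccc3c2)C(=O)NS(=O)(=O)c2cccc(S(N)(=O)=O)c2)ccc1OC(C)C`: > 5000 nM
- compound 2 `CCOc1cc(C(Nc2ccc3cnccc3c2)C(=O)NS(=O)(=O)c2cccc(S(N)(=O)=O)c2)ccc1OC(C)C`: > 5000 nM

Compound 2 stands only at a limit of this assay, > 5000 nM. The step that the two limits leave unreadable from compound 1 to compound 2 cannot be read, because the limit of > 5000 nM in this assay, at which 2 of the 2 values shown sit, and because of the fact that one of compounds 1 and 2 is drawn with a defined configuration and the other without, at the place where they differ. Compound 3 `CCOc1cc(C(Nc2ccc3cnccc3c2)C(=O)NS(=O)(=O)c2ccc(S(C)(=O)=O)cc2)ccc1OC(C)C` carries the change (4-(methylsulfonyl)phenyl in place of 3-sulfamoylphenyl on a sulfonyl sulfur). Among the compounds with values here, no measured step bears on this exchange on the sulfonyl sulfur, so no direction can be drawn from the values shown. Compound 3 is therefore expected to stay at or near the limit, with an estimated value of 8000 nM (range 2000 nM to 30000 nM), an expected step that the limit leaves unreadable from compound 2 to compound 3 from compound 2 to compound 3.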

Compound 3, inhibition constant: > 5000 nM
Compound 3 ended at the assay's limit; the forecaster's own chance of this, stated with the estimate: 70%; the middle value is on the limit's open side.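

No step can be read from compound 2 to compound 3 in this assay, because both compounds sit at the assay limit: the limit of > 5000 nM in this assay, at which 3 of the 3 values shown sit.

The compounds shown leave open whether 3-sulfamoylphenyl and 4-(methylsulfonyl)phenyl differ at all in this assay.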